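Amino-acid substituents on the stilbene ether: compound 4

The compounds below may be only part of what the source reports. "The series", "measured", "known", "first", "only" and "open" are said of these compounds alone.

Measured compounds in this study:
compound 1 `COc1ccc(/C=C\c2cc(OC)c(OC)c(OC)c2)cc1OCc1ccc(C=O)cc1`: 900 nM
compound 2 `COc1ccc(/C=C\c2cc(OC)c(OC)c(OC)c2)cc1OCc1ccc(CN2CCCC[C@@H]2C(=O)O)cc1`: > 10000 nM
compound 3 `COc1ccc(/C=C\c2cc(OC)c(OC)c(OC)c2)cc1OCc1ccc(CN2CC[C@@H](C(=O)O)C2)cc1`: 6300 nM

The three compounds share one core and differ only in the group carried on the benzylic carbon. In a functional assay on MC-38 cells (Mus musculus) for antiproliferative activity, read by CCK-8 assay, with a stated time of 48 h (on this read-out higher numbers stand for weaker inhibition and lower numbers for stronger inhibition), compound 1, bearing the formyl group, gives 900 nM. Compound 2 reaches only a limit of the assay, > 10000 nM, with no number behind it (the limit of > 10000 nM in this assay, at which 1 of the 3 values shown sits). Compound 3 gives 6300 nM. The two steps from the formyl compound are both beyond the scatter: an at least 11-fold higher number from compound 1 to compound 2 (1.04 log units; beyond the scatter) and a 7.0-fold higher number from compound 1 to compound 3 (0.85 log units; beyond the scatter). Between the two amino-acid compounds the step is an at least 1.5-fold lower number from compound 2 to compound 3 (0.20 log units; that floor lies within the scatter), and its floor lies within the scatter, so compound 2 and compound 3 cannot be ordered against each other on these numbers.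

Compound 4 `COc1ccc(/C=C\c2cc(OC)c(OC)c(OC)c2)cc1OCc1ccc(CN[C@H](C(=O)O)[C@@H](C)O)cc1` has not yet been measured. It differs from compound 2 by (1-carboxy-2-hydroxypropyl)amino in place of 2-carboxypiperidin-1-yl on a saturated chain carbon bound to an aromatic carbon. Both the group that leaves and the group that enters carry a carboxylic acid on a nitrogen-bearing carbon, as does the group in compound 3. Within the data shown here, the steps that bear on this change, from compound 1 to compound 2 and from compound 1 to compound 3, both point to weak inhibition for such groups, and the step from compound 2 to compound 3 gives no reliable direction within that pair. Compound 4 is therefore expected to remain in the weak region, with a step estimated as an at least 1.2-fold lower number from compound 2 to compound 4 (0.09 log units; that floor lies within the scatter). The estimate for compound 4 in this assay is 8000 nM, with a range from 2500 nM to 25000 nM, and a real chance that only a limit is reported.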

Compound 4, half-maximal inhibitory concentration: > 10000 nM
Compound 4: no number, only a limit (the forecaster's own chance of this, stated with the estimate: 40%); middle value at least 1.2-fold (0.09 log units) from the limit.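

In this assay compound 4 gives only a limit, > 10000 nM, and no number, so a second amino-acid compound now stands at the same edge of the range: the limit of > 10000 nM in this assay, at which 2 of the 4 values shown sit. Both compound 2 and compound 4 are limits, so the step between them cannot be read, and the exchange of 2-carboxypiperidin-1-yl for (1-carboxy-2-hydroxypropyl)amino shows no recovery of inhibition that this read-out can register. What is new is that a group with no ring and with an added hydroxyl also lies well away from the formyl compound, with an at least 11-fold higher number from compound 1 to compound 4 (1.04 log units; beyond the scatter), while an at least 1.5-fold higher number from compound 3 to compound 4 (0.20 log units; that floor lies within the scatter) leaves the two unordered, so the weak result seen with the two ring-bearing amino acids is not confined to groups with a ring.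

The compounds shown leave open whether the weak inhibition goes with the carboxylic acid or with the amine on the saturated chain carbon. A plain amine such as morpholine at that place, or the methyl ester of one of these amino acids, would separate the two.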